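Difluorophenyl in Place of Methoxyphenyl: What Compound 3 May Give

The source may report more compounds than this note shows. Statements on the series, on what has been measured and on what is new or still open speak of the compounds shown alone.

Compound 1 `COc1ccc(C(=O)c2cc(OC)c(OC)c(OC)c2)cc1NC(=O)/C=C/c1ccc(OC)c(OC)c1`: in a functional assay on COLO 205 cells (Homo sapiens) for cytotoxicity, read by MTT assay, with a stated time of 72 h (a higher number here means a weaker inhibitor, a lower number a stronger inhibitor), compound 1 gives 8200 nM.
Compound 2 `COc1ccc(/C=C/C(=O)Nc2cc(C(=O)c3cc(OC)c(OC)c(OC)c3)ccc2OC)cc1`: in this assay compound 2 gives 10900 nM.

Among the two measured compounds, compound 2 stands with the highest number; its nearest neighbour is compound 1, and the step of a 1.3-fold higher number from compound 1 to compound 2 (0.12 log units; within the scatter) lies within the scatter, so the two cannot be ranked against each other. Compound 3 `COc1ccc(C(=O)c2cc(OC)c(OC)c(OC)c2)cc1NC(=O)/C=C/c1ccc(F)c(F)c1` differs from compound 2 by 3,4-difluorophenyl in place of 4-methoxyphenyl on a double-bonded chain carbon bound to a double-bonded chain carbon. Within the data shown here, no measured step concerns this part of the molecule: the only step in hand, a 1.3-fold higher number from compound 1 to compound 2 (0.12 log units; within the scatter), exchanges a methoxy for hydrogen on a different part of the structure and was within the scatter. With nothing in the data pointing to a shift, compound 3 is expected to stay close to compound 2, with no step beyond the scatter, namely a 1.1-fold lower number from compound 2 to compound 3 (0.04 log units; within the scatter). Compound 3 is therefore estimated at 10000 nM, with a range from 4000 nM to 25000 nM.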

Compound 3, half-maximal inhibitory concentration: 6020 nM
Beside the measured number, compound 3's estimate is 1.7-fold (0.22 log units) above it, within the range that was stated.
By their numbers in this assay, from the lowest: compounds 3, 1 and 2 (each within the scatter of the next).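

The exchange on the ring carried by the double-bonded chain now reaches beyond methoxy groups: 3,4-difluorophenyl in place of 4-methoxyphenyl gives a 1.8-fold lower number from compound 2 to compound 3 (0.26 log units; within the scatter) and 3,4-difluorophenyl in place of 3,4-dimethoxyphenyl gives a 1.4-fold lower number from compound 1 to compound 3 (0.13 log units; within the scatter) in this assay. With both steps within the scatter, a ring bearing two fluorines cannot be told apart from either methoxy-bearing ring, so this position has so far shown no readable shift, whichever of the three rings it carries. No evidence is available that bears on this result.

Going by these compounds, whether any group at this position can move the number beyond the scatter remains open. An amine or a carboxylic acid on this ring, or a longer chain in place of the 2-(3,4-difluorophenyl)ethenyl group, would put that question to this assay.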